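The source may report more compounds than this note shows. Statements on the series, on what has been measured and on what is new or still open speak of the compounds shown alone.

Three related compounds have been tested so far in a functional assay on RXF 393 cells (Homo sapiens) for inhibition, with a stated time of 48 h; a lower number here means a stronger inhibitor of growth, a higher number a weaker inhibitor of growth. Compound 1 `COc1ccccc1/C=C/C(=O)c1c(O)cc2occc2c1OC` gives 14900 nM there, and compound 2 `COc1c(C(=O)/C=C/c2ccc(Cl)cc2)c(O)c(Br)c2occc12` gives 2370 nM in the same test. Compound 3 `C=CCc1c(O)c(C(=O)/C=C/c2ccccc2)c(OC)c2ccoc12` gives 1850 nM and so stands level with compound 2, since their two values lie within the usual scatter of repeated measurements. Compound 1 is clearly the weaker inhibitor of growth when set against compound 3, by a gap well beyond that scatter.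

The next molecule, compound 4 `C=CCc1c(O)c(C(=O)/C=C/c2ccc(Cl)cc2)c(OC)c2ccoc12`, is compound 3 with a single alteration: chloro in place of hydrogen on an aromatic carbon. This is chloro in place of hydrogen on an aromatic carbon, para to a large group, which turns phenyl into 4-chlorophenyl.

Going by the values given here, no measured pair shows this change on its own, so the data give no direct size for it. Among the compounds with values here, the only hint is compound 2, which also carries a 4-chlorophenyl group and gives 2370 nM in this assay, a number that cannot be told apart from that of compound 3. That is weak evidence, but it points to no step beyond the scatter. The expected change is small, a 1.2-fold lower number from compound 3 to compound 4 (0.09 log units; within the scatter), and would stay within that scatter. For compound 4 the estimated value is 1500 nM, with an expected range from 700 nM to 3200 nM.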

Compound 4, concentration for 50% growth inhibition: 1720 nM
Compound 4: the middle estimate sits 1.1-fold (0.06 log units) below what was measured; the measured number falls inside the stated range.
By their numbers in this assay, from the lowest: compounds 4, 3 and 2 (each within the scatter of the next); then compound 1.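

Replacing hydrogen with chloro on this aromatic carbon, para to a large group, now has a direct measure in this assay: turning phenyl into 4-chlorophenyl gives a 1.1-fold lower number from compound 3 to compound 4 (0.03 log units; within the scatter) and so leaves growth inhibition indistinguishable in this test. The second pair keeps the 4-chlorophenyl group fixed and exchanges a different substituent on an aromatic carbon, with allyl in place of bromo giving a 1.4-fold lower number from compound 2 to compound 4 (0.14 log units; within the scatter), which also stays within the scatter, so these two groups cannot be told apart here either, at least with 4-chlorophenyl in place. Nothing available explains why either swap leaves the number within the scatter.

From the compounds shown here alone, whether an amine or a carboxylic acid on the same carbon that carries chloro, or a longer chain in place of allyl, would produce a step beyond the scatter remains open. Going by these compounds, it is also open whether chloro and allyl would behave the same way on the core of compound 1, which gives 14900 nM and differs from compound 4 in more than one place.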